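Amine Demethylation on a Weak T-Type Channel Blocker

The source may report more compounds than this note shows. Statements on the series, on what has been measured and on what is new or still open speak of the compounds shown alone.

Compound 1 `CN(C)CCCOc1ccc(CNc2nc3ccc(Oc4cccc(C(F)(F)F)c4)cc3s2)cc1` gives 110000 nM in an assay on cells for inhibition of Voltage-dependent T-type calcium channel subunit alpha-1H (Homo sapiens), read by FLIPR and calcium flux, with stated times of 600 s and 300 s; on this read-out lower numbers stand for stronger inhibition and higher numbers for weaker inhibition.
Compound 2 `CN(C)CCCOc1ccc(CNc2nc3ccc(Oc4ccc(C#N)cc4)cc3s2)cc1` gives 41000 nM in this assay.

Among the compounds with values here, compound 1 stands as the higher of the two numbers; the only step known, a 2.7-fold lower number from compound 1 to compound 2 (0.43 log units; beyond the scatter), changes a different part of the molecule. Compound 3 `NCCCOc1ccc(CNc2nc3ccc(Oc4cccc(C(F)(F)F)c4)cc3s2)cc1` differs from compound 1 by amino in place of dimethylamino on a saturated chain carbon, three bonds along the chain from an oxygen on an aromatic ring. Within the data shown here, no measured step touches this chain end, so nothing shows which way the number should move. Compound 3 is therefore expected to stay near compound 1, a step of no change at the digits printed from compound 1 to compound 3 (within the scatter), not beyond the scatter. The estimate for compound 3 is 110000 nM, in the range 35000 nM to 350000 nM.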

Compound 3, half-maximal inhibitory concentration: 171000 nM
For compound 3 the middle estimate is 1.6-fold (0.19 log units) below the measured one; the range from low to high includes it.
By their numbers in this assay, from the lowest: compound 2; then compounds 1 and 3 (each within the scatter of the next).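

In this assay, 3-aminopropyl in place of 3-(dimethylamino)propyl gives a 1.6-fold higher number from compound 1 to compound 3 (0.19 log units; within the scatter). Within the data shown here, this is the first measured step at this position, and it shows that this change does not separate the two compounds on this read-out. Nothing available bears on why the result came out this way. The compounds shown leave open whether a morpholine, a piperidine or a carboxylic acid at this position, or a longer chain carrying the amine, would move the number beyond the scatter. They also leave open whether the same exchange would give a similar step on compound 2, which carries 4-cyanophenyl.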